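Swapping 3-Fluorophenyl for Pyridin-3-yl on the Shared Core

A few compounds are considered here, and "the series" means these few. Any claim that something is new, unique, unknown or untested is made for them only; others in the source may bear on it.

Measured compounds:
- compound 1 `O=C(NCCCNc1nc(Nc2cccc(F)c2)ncc1C1CC1)C1CCC1`: 1300 nM
- compound 2 `CN1CCC(c2ccc(Nc3ncc(C4CC4)c(NCCCNC(=O)C4CCC4)n3)cc2)CC1`: 660 nM
- compound 3 `O=C(NCCCNc1nc(Nc2ccc(-n3cncn3)cc2)ncc1C1CC1)C1CCC1`: 150 nM

In an assay on RAW264.7 cells for inhibition of serine/threonine-protein kinase TBK1 (Mus musculus), read by ELISA, with stated times of 30 min and 6 h (on this read-out higher numbers stand for weaker inhibition and lower numbers for stronger inhibition), compound 1 gives 1300 nM, the highest of the three numbers. Compound 2 sits close by, within the usual scatter, so no order between compound 1 and compound 2 can be claimed. Compound 3 lies furthest away, beyond the scatter.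

The unmeasured compound 4 `O=C(NCCCNc1nc(Nc2cccnc2)ncc1C1CC1)C1CCC1` differs from compound 1 in one place: pyridin-3-yl in place of 3-fluorophenyl on a nitrogen on an aromatic ring.

Within the data shown here, only one measured step changes this part of the molecule, a 4.4-fold lower number from compound 2 to compound 3 (0.64 log units; beyond the scatter), where 1H-1,2,4-triazol-1-yl replaced 1-methylpiperidin-4-yl on an aromatic carbon. That step swapped a whole group attached to the ring, whereas the change to compound 4 exchanges a ring carbon bearing fluorine for a ring nitrogen, so it is only a loose guide. Among the measured compounds shown here, no step among the measured compounds tests a ring nitrogen directly. The expectation is therefore cautious: a step of a 1.2-fold lower number from compound 1 to compound 4 (0.07 log units; within the scatter) is estimated, which is within the scatter and so no real change.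

Compound 4 is expected to give about 1100 nM, with a plausible range from 400 nM to 3000 nM.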

Compound 4, half-maximal inhibitory concentration: > 1000 nM
Compound 4: only a limit was reported; the forecaster's own chance of this, stated with the estimate: 5%; the middle value does not contradict the limit.
By their numbers in this assay, from the lowest: compound 3; then compounds 2 and 1 (each within the scatter of the next).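

Compound 4 is reported only as a limit, > 1000 nM, and not as a number, so the step from compound 1 to compound 4 cannot be read: the limit of > 1000 nM in this assay, at which 1 of the 4 values shown sits. The compounds shown leave open whether pyridin-3-yl in place of 3-fluorophenyl changes the number at all, and if so, in which direction and by how much.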